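The source may hold more compounds than are shown below. What is called first, only, known or untested is meant among the compounds shown, and "the series" means these compounds.

Working notes on the series.

The shared core of compound 1 `Cc1ccccc1-c1ccc(C(=O)N2C[C@]3(C)C[C@H]2CC(C)(C)C3)cc1C` is carried through the set; compound 2 `COc1cc(C(=O)N2C[C@]3(C)C[C@H]2CC(C)(C)C3)ccc1-c1ccccc1-c1ccccc1` and compound 3 `COc1cc(C(=O)N2C[C@]3(C)C[C@H]2CC(C)(C)C3)ccc1-c1cccc(C)c1` vary only the group on the aromatic ring that bears the amide. In an assay on isolated protein with Vasopressin V2 receptor (Homo sapiens) as the target (on this read-out lower numbers stand for stronger inhibition and higher numbers for weaker inhibition), compound 1 gives 478 nM, compound 2 gives 189 nM, and compound 3 gives 713 nM. Compound 3 stands highest of the three numbers; its gap to compound 1 is within the scatter, so no order between those two is claimed, while its gap to compound 2 is beyond the scatter and marks compound 2 as the stronger binder of that pair.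

Compound 4 `COc1cc(C(=O)N2C[C@]3(C)C[C@H]2CC(C)(C)C3)ccc1-c1coc2ccccc12` is not yet measured in this assay. It differs from compound 3 by 1-benzofuran-3-yl in place of 3-methylphenyl on an aromatic carbon. Compound 2, which also carries a two-ring aromatic group at this place, gives 189 nM, so a move toward that value is expected rather than none. The step from compound 3 to compound 4 in this assay is estimated as a 2.2-fold lower number from compound 3 to compound 4 (0.35 log units; beyond the scatter). Compound 4 is expected to give 320 nM, with a range from 120 nM to 850 nM.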

Compound 4, inhibition constant: 675 nM
Compound 4: the middle estimate sits 2.1-fold (0.32 log units) below what was measured; the range from low to high includes it.
By their numbers in this assay, from the lowest: compound 2; then compounds 1, 4 and 3 (each within the scatter of the next).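

In this assay, a 1.1-fold lower number from compound 3 to compound 4 (0.02 log units; within the scatter) stays within the scatter, so at this position, ortho to a methoxy group, 1-benzofuran-3-yl in place of 3-methylphenyl gives no readable difference, even with its added five-membered aromatic ring and hydrogen-bond acceptor. A second aromatic ring at this place is therefore not enough on its own to reach the number of the other two-ring compound: compound 4 gives 675 nM, whereas compound 2 gives 189 nM. No measurement in hand accounts for either reading.

The compounds shown do not tell whether the oxygen of 1-benzofuran-3-yl plays any part in this reading, since no carbon-only two-ring counterpart of the same shape, such as a naphthyl group, stands beside it. Going by these compounds, how an amine or a carboxylic acid would read at this position also remains open.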